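The source may report more compounds than this note shows. Statements on the series, on what has been measured and on what is new or still open speak of the compounds shown alone.

Compound 1 `Cc1cc(Nc2cc(-c3ccccc3)[nH]n2)n2nc(SCc3ccc(Cl)cc3)nc2n1` gives 8260 nM in a functional assay on MCF7 cells (Homo sapiens) for inhibition, read by MTT assay, with a stated time of 72 h; a lower number here means a stronger inhibitor, a higher number a weaker inhibitor.
Compound 2 `Cc1cc(Nc2cc(-c3ccc(Cl)cc3)[nH]n2)n2nc(SCc3ccc(Br)cc3)nc2n1` gives 3620 nM in this assay.
Compound 3 `CCCSc1nc2nc(C)cc(Nc3cc(-c4ccccc4)[nH]n3)n2n1` gives > 50000 nM in this assay, which is a limit of the assay rather than a number.

Compound 3 therefore stands at the weak end of what has been measured and is known only as a limit (the limit of > 50000 nM in this assay, at which 1 of the 3 values shown sits). The unmeasured compound 4 `Cc1cc(Nc2cc(-c3ccccc3)[nH]n2)n2nc(SCc3ccc(Br)cc3)nc2n1` differs from compound 3 in one place: 4-bromophenyl in place of ethyl on a saturated chain carbon bound to a sulfur. Going by the values given here, one measured step bears directly on this change, run in the opposite direction: an at least 6.0-fold higher number from compound 1 to compound 3 (0.78 log units; beyond the scatter), where removing a closely related aryl group from the same carbon pushed the number out of the measurable range. Compound 2, which carries the (4-bromobenzyl)sulfanyl group, gives 3620 nM. Restoring the 4-bromophenyl is therefore expected to bring the number down by a step of roughly the size an at least 8.3-fold lower number from compound 3 to compound 4 (0.92 log units; beyond the scatter). Compound 4 is thus estimated at 6000 nM, with a range of 2500 nM to 15000 nM.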

Compound 4, half-maximal inhibitory concentration: 2720 nM
Estimate against measurement, compound 4: 2.2-fold (0.34 log units) above; the measured number falls inside the stated range.
By their numbers in this assay, from the lowest: compounds 4 and 2 (each within the scatter of the next); then compound 1. At a limit, above all of these: compound 3.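

Putting 4-bromophenyl in place of ethyl on the saturated chain carbon bound to a sulfur gives an at least 18-fold lower number from compound 3 to compound 4 (1.26 log units; beyond the scatter) in this assay, and the size of this large step is only a bound, since one end of it is a limit: the limit of > 50000 nM in this assay, at which 1 of the 4 values shown sits. Among the compounds that keep an aryl group on that carbon, bromo in place of chloro on an aromatic carbon gives a 3.0-fold lower number from compound 1 to compound 4 (0.48 log units; beyond the scatter), a modest step beyond the scatter. Hydrogen in place of chloro on an aromatic carbon gives a 1.3-fold lower number from compound 2 to compound 4 (0.12 log units; within the scatter), so chloro and hydrogen at that place cannot be told apart here.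

From the compounds shown here alone, how much of the gain comes from the ring and how much from the bromine stays open, as a plain phenyl on the same carbon would be needed to separate them. Also open, going by these compounds, is how an amine, a carboxylic acid or a longer chain would fare there.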